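Fluorine position on the anilino ring of compound 1

This account rests on a few compounds, and the source may have more. Where it says the series, first, only, none or still open, it means among the compounds named here.

Compound 1 `O=C(NCCCNc1nc(Nc2cccc(F)c2)ncc1C1CC1)c1cccs1` gives the highest number of the three measured in an assay on isolated protein for inhibition of serine/threonine-protein kinase TBK1 (Homo sapiens) (a higher number here means a weaker inhibitor, a lower number a stronger inhibitor), at 110 nM. Compound 2 `O=C(NCCCNc1nc(Nc2cccc(F)c2)ncc1C1CC1)C1CCC1` gives 8 nM and compound 3 `O=C(NCCCNc1nc(Nc2cccc(F)c2)ncc1Br)c1cccs1` gives 9 nM; the steps of a 14-fold lower number from compound 1 to compound 2 (1.14 log units; beyond the scatter) and a 12-fold lower number from compound 1 to compound 3 (1.09 log units; beyond the scatter) both concern other parts of the shared core, the carbonyl substituent and the substituent on the aromatic carbon. Compound 4 `O=C(NCCCNc1nc(Nc2ccccc2F)ncc1C1CC1)c1cccs1` differs from compound 1 only at the aniline nitrogen: 2-fluorophenyl in place of 3-fluorophenyl on a nitrogen on an aromatic ring. Among the measured compounds shown here, no measured step touches this position, so the series offers no direction for it; the step is expected to stay within the scatter of this assay, a 1.4-fold higher number from compound 1 to compound 4 (0.13 log units; within the scatter). Compound 4 is therefore estimated at 150 nM, with a range from 50 nM to 500 nM.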

Compound 4, half-maximal inhibitory concentration: 820 nM
Compound 4: the middle estimate sits 5.5-fold (0.74 log units) below what was measured; measured number above the stated range.
By their numbers in this assay, from the lowest: compounds 2 and 3 (each within the scatter of the next); then compound 1; then compound 4.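

The anilino position is not indifferent in this assay: moving the fluorine gives a 7.5-fold higher number from compound 1 to compound 4 (0.87 log units; beyond the scatter) and the change goes toward a weaker inhibitor. The leaving and entering groups have the same atoms and counts, so the place of the fluorine on the phenyl ring alone separates these two compounds. Nothing at hand accounts for this loss.

On these data alone, whether plain phenyl or a phenyl bearing chlorine would hold the level of compound 1 remains open. Also open, as far as these compounds go, is whether the same fluorine shift costs as much alongside the cyclobutyl of compound 2 or the bromo of compound 3.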